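Sulfur-linked chain variants in a cell growth inhibition series

A few compounds are considered here, and "the series" means these few. Any claim that something is new, unique, unknown or untested is made for them only; others in the source may bear on it.

Measured so far:
compound 1 `CCCSc1nc2nc(C)cc(N3CC[C@@H](C)[C@@H](N(C)c4ncnc5[nH]ccc45)C3)n2n1` — 20900 nM
compound 2 `C[C@@H]1CCN(c2cc(-c3ccccc3)nc3ncnn23)C[C@@H]1N(C)c1ncnc2[nH]ccc12` — > 100000 nM

Within the data shown here, in a functional assay on HGC-27 cells (Homo sapiens) for inhibition, read by MTT assay, with a stated time of 72 h (a higher number here means a weaker inhibitor, a lower number a stronger inhibitor), compound 1 gives 20900 nM, the only numeric value in the set. Compound 2 reaches only the assay limit, > 100000 nM, and is read as a limit and not as a number (the limit of > 100000 nM in this assay, at which 1 of the 2 values shown sits). Compound 3 `Cc1cc(N2CC[C@@H](C)[C@@H](N(C)c3ncnc4[nH]ccc34)C2)n2nc(SCC3CC3)nc2n1` differs from compound 1 by cyclopropyl in place of ethyl on a saturated chain carbon bound to a sulfur. Among the measured compounds shown here, no measured pair differs in a single place, so no step size is on record for this assay. For a change of this kind the expected step is small, within the scatter, in no set direction: a 1.2-fold lower number from compound 1 to compound 3 (0.06 log units; within the scatter). Compound 3 is therefore expected near 18000 nM, between 7000 nM and 50000 nM.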

Compound 3, half-maximal inhibitory concentration: 21400 nM
Beside the measured number, compound 3's estimate is 1.2-fold (0.08 log units) below it; the measured number falls inside the stated range.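

In this assay the series gains its first step between compounds that differ in one place: a 1.0-fold higher number from compound 1 to compound 3 (0.01 log units; within the scatter) with cyclopropyl in place of ethyl on a saturated chain carbon bound to a sulfur. At this position, propylsulfanyl and (cyclopropylmethyl)sulfanyl read alike, so this change, which adds one three-membered ring, leaves no readable difference. Nothing measured here offers a cause for this result.

Still open, from the compounds shown here alone, is whether an amine or a carboxylic acid in this place would separate from these two compounds. Going by these compounds, a longer chain on the sulfur is equally open.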